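Swapping the Amide Aryl Group on a Shared Core

This account rests on a few compounds, and the source may have more. Where it says the series, first, only, none or still open, it means among the compounds named here.

Compound 2 `C=CC(=O)Nc1cccc(NC(=O)CSc2nc(Nc3ccccc3)c3ccccc3n2)c1` gives 8120 nM in a functional assay on NCI-H1975 cells (Homo sapiens) for inhibition, read by MTT assay, with a stated time of 72 h; a lower number here means a stronger inhibitor, a higher number a weaker inhibitor. Its only comparator, compound 1 `CCc1cccc(NC(=O)CSc2nc(Nc3ccccc3)c3ccccc3n2)c1`, gives 12000 nM, and the step of a 1.5-fold lower number from compound 1 to compound 2 (0.17 log units; within the scatter) lies within the scatter, so the two stand level. Compound 3 `O=C(CSc1nc(Nc2ccccc2)c2ccccc2n1)Nc1ccc(C(F)(F)F)cc1` differs from compound 2 by 4-(trifluoromethyl)phenyl in place of 3-((vinylcarbonyl)amino)phenyl on an amide-type nitrogen. Among the compounds with values here, the one measured step changes a substituent on that same ring rather than replacing the ring, so it bears only loosely on this change; being within the scatter, it gives no ground to expect a move beyond the scatter in this assay. Compound 3 is therefore estimated at 10000 nM, between 3000 nM and 35000 nM, an expected step of a 1.2-fold higher number from compound 2 to compound 3 (0.09 log units; within the scatter).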

Compound 3, half-maximal inhibitory concentration: 11700 nM
Compound 3: middle estimate off by 1.2-fold (0.07 log units), on the low side; low and high end bracket the measured number.
By their numbers in this assay, from the lowest: compounds 2, 3 and 1 (each within the scatter of the next).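

Replacing the whole aryl group on the amide-type nitrogen, rather than a substituent on it, leaves the number in this assay within the scatter (a 1.4-fold higher number from compound 2 to compound 3 (0.16 log units; within the scatter)) and (a 1.0-fold lower number from compound 1 to compound 3 (0.01 log units; within the scatter)). At this position 4-(trifluoromethyl)phenyl, with 0 hydrogen-bond donors and 0 hydrogen-bond acceptors, thus stands level with both 3-((vinylcarbonyl)amino)phenyl and 3-ethylphenyl. No measurement shown here accounts for this result.

As far as these compounds go, whether an amine or a carboxylic acid on this aryl ring would move the number beyond the scatter remains open. So does the effect of any change to the shared core.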